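Swapping ethyl for 4-bromophenyl at the assay's limit

The source may report more compounds than this note shows. Statements on the series, on what has been measured and on what is new or still open speak of the compounds shown alone.

This piece follows a small pair of compounds through an ADME assay on L02 cells (Homo sapiens) for cytotoxicity, read by MTT assay; on this read-out lower numbers stand for stronger inhibition and higher numbers for weaker inhibition. Compound 1 `C#CCOc1cc(/C=C/C(=O)c2ccc(OC)c3c2OC(C)(C)C=C3)ccc1OC` gives > 10000 nM as its reading, which is a limit of the assay and not a number. Compound 2 `CCC(=O)Oc1cc(/C=C/C(=O)c2ccc(OC)c3c2OC(C)(C)C=C3)ccc1OC` gives > 10000 nM as its reading, and this too is only a limit. Within the data shown here, compound 2 therefore has no exact position, and the one other value beside it is also a limit.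

Compound 3 `COc1ccc(/C=C/C(=O)c2ccc(OC)c3c2OC(C)(C)C=C3)cc1OC(=O)c1ccc(Br)cc1` keeps the rest of compound 2 and changes in one place: 4-bromophenyl in place of ethyl on a carbonyl carbon. In plain words, 4-bromophenyl stands in place of ethyl on a carbonyl carbon.

Among the measured compounds shown here, the only measured step is a step that the two limits leave unreadable from compound 1 to compound 2 and it gives no size to carry forward. It is a different change as well, and the whole picture so far is the limit of > 10000 nM in this assay, at which 2 of the 2 values shown sit. No clear shift is therefore expected in this assay, and another limit is the likeliest report. The expected step is a step that the limit leaves unreadable from compound 2 to compound 3 and no larger shift can be argued from these data. For compound 3 the estimated value is 15000 nM with an expected range from 6000 nM to 40000 nM.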

Compound 3, half-maximal inhibitory concentration: 8400 nM
For compound 3 the middle estimate is 1.8-fold (0.25 log units) above the measured one; measured number inside the range.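

In this assay compound 3 gives 8400 nM, a real number rather than a limit, so this series now has one reading that can be placed on the scale. The change on the carbonyl carbon reads as an at least 1.1-fold lower number from compound 2 to compound 3 (0.07 log units; that floor lies within the scatter), and the larger replacement on the oxygen on the aromatic ring reads as an at least 1.1-fold lower number from compound 1 to compound 3 (0.07 log units; that floor lies within the scatter); neither floor shows a shift beyond the scatter, though the true sizes could be larger. The two steps can be given only as floors, and a single measured number cannot show how far 4-bromophenyl really moves the reading, since the other readings are limits: the limit of > 10000 nM in this assay, at which 2 of the 3 values shown sit.

The compounds shown leave open whether any change in the reading belongs to the aromatic ring or to its bromine, a question that a plain phenyl or a 4-chlorophenyl on the same carbonyl carbon could help to settle. They also leave open how this position would respond to a quite different group there, such as an amine or a carboxylic acid.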